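Methoxy on the anilino ring of a weak antiproliferative

The source may hold more compounds than are shown below. What is called first, only, known or untested is meant among the compounds shown, and "the series" means these compounds.

For the measured compounds named here, the shared core is seen in compound 1 `Cc1nc(SCC(=O)Nc2nc(-c3ccc(Cl)cc3)cs2)n(Nc2ccccc2)c1C`, which in a functional assay on M14 cells (Homo sapiens) for antiproliferative activity, read by sulforhodamine B assay, with a stated time of 48 h (a lower number here means that less compound is tolerated, a higher number that more compound is tolerated), gives 51200 nM, the only measured number among the compounds described here. Compound 2 `Cc1ccc(Nn2c(SCC(=O)Nc3nc(-c4ccccc4)cs3)nc(C)c2C)cc1` carries a methyl in place of the chlorine and a methyl on the anilino ring; in this assay compound 2 reaches only > 100000 nM, which is a limit of the measurement and not a number. Thus (the limit of > 100000 nM in this assay, at which 1 of the 2 values shown sits). Together the two values show that neither compound is tolerated poorly: both sit at high concentrations, one at the upper edge of what the assay can report.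

Compound 3 `COc1ccc(Nn2c(SCC(=O)Nc3nc(-c4ccc(Cl)cc4)cs3)nc(C)c2C)cc1` differs from compound 1 by methoxy in place of hydrogen on an aromatic carbon. No measured step of this kind exists among the compounds shown, so the expectation rests on compound 1 alone. Compound 3 is expected to behave much like compound 1, with a step from compound 1 to compound 3 of a 1.4-fold higher number from compound 1 to compound 3 (0.14 log units; within the scatter), which is not beyond the scatter. Compound 3 is therefore estimated at 70000 nM, between 30000 nM and 160000 nM, with a real chance that only a limit is reported.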

Compound 3, concentration lethal to 50% of the cells: > 100000 nM
Compound 3: no number, only a limit (the forecaster's own chance of this, stated with the estimate: 40%); at least 1.4-fold (0.15 log units) between middle value and limit.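

In this assay, for the compounds shown here, methoxy on the anilino ring, para to a large group, gives an at least 1.9-fold higher number from compound 1 to compound 3 (0.29 log units; that floor lies within the scatter), the only step at this position that can be read. Compound 3 yields a limit and not a number, so this step has a floor but no top: the change from phenyl to 4-methoxyphenyl may be small or much larger, and the data do not decide between the two. It does show that, with methoxy at this position, the compound gives no measurable number within the range of the assay, and any reading of this position is bounded by that range: the limit of > 100000 nM in this assay, at which 2 of the 3 values shown sit.

Going by these compounds, how far compound 3 truly lies past the limit stays open, and with it whether the step goes beyond the scatter at all. Going by these compounds alone, also open is whether another group on the same aromatic carbon, such as an amine, a carboxylic acid or a chlorine, would give a measured number in this assay, and whether that number would fall on either side of the one for compound 1.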